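A few compounds are considered here, and "the series" means these few. Any claim that something is new, unique, unknown or untested is made for them only; others in the source may bear on it.

Working notes on the series. Of the compounds shown here, two of this type have been measured in a toxicity assay on Vero C1008 cells (Chlorocebus sabaeus) for cytotoxicity, read by neutral red uptake, with a stated time of 5 days; a lower number here means that less compound is tolerated, a higher number that more compound is tolerated. Compound 1 `CC(C)(C)c1ccc(N(C(=O)c2ccco2)C(C(=O)NC2CC2)c2cccnc2)cc1` gives 52800 nM in this assay. Compound 2 `C[C@H](NC(=O)C(c1cccnc1)N(C(=O)c1ccco1)c1ccc([Si](C)(C)C)cc1)c1ccccc1` gives 19400 nM in this assay, the lowest of the two numbers; its nearest neighbour is compound 1, whose number lies beyond the scatter above it. Among the measured compounds shown here, no pair of measured compounds differs in a single place, so no measured step is available to lean on.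

Compound 3 `C[C@H](NC(=O)C(c1cccnc1)N(C(=O)c1ccco1)c1ccc(C2CCCCC2)cc1)c1ccccc1` differs from compound 2 in one place: a group of 6 heavy atoms (6 carbon; one six-membered non-aromatic ring of carbon only) in place of a group of 4 heavy atoms (3 carbon, 1 silicon; no ring), on an aromatic carbon. The change swaps one group of similar size for another and adds a ring where none was. For the measured compounds named here, with no directly comparable step in hand, the expectation for the step from compound 2 to compound 3 in this assay is none beyond the scatter, written as a 1.0-fold higher number from compound 2 to compound 3 (0.01 log units; within the scatter). Compound 3 is thus expected at about 20000 nM, with a range from 8000 nM to 50000 nM.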

Compound 3, half-maximal cytotoxic concentration: 9610 nM
The estimate for compound 3 lay 2.1-fold (0.32 log units) above the measured number; measured number inside the range.
By their numbers in this assay, from the lowest: compound 3; then compound 2; then compound 1.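

Among the compounds shown here, measured in this assay the change gives a 2.0-fold lower number from compound 2 to compound 3 (0.31 log units; beyond the scatter) and is the first single-place step, showing that the group on this aromatic carbon, para to a large group, can shift the number beyond the scatter. The shift is modest, and it appears with cyclohexyl replacing a group of similar size, with both groups counted as having no hydrogen-bond donors or acceptors and no net charge. No measurement available here accounts for the step.

On these data alone, whether the same direction holds for other groups at this position, such as an amine, a carboxylic acid or a longer straight chain, remains open. Compound 1 differs from compound 2 and compound 3 in more than one place, so the contribution of the amide side of the core also remains unresolved.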